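Capping a Phenol as Methyl Ether: Expected Cytotoxicity Shift

The source may hold more compounds than are shown below. What is called first, only, known or untested is meant among the compounds shown, and "the series" means these compounds.

Compound 1 `COc1cccc(-c2nc(-c3ccc(OC)c(OC)c3)cc3cc(C)ccc23)c1` is the starting point of this small series. In an ADME assay on MCF-10A cells (Homo sapiens) for cytotoxicity, read by CCK-8 assay and cell counting, with a stated time of 72 h (a lower number here means a stronger inhibitor, a higher number a weaker inhibitor), compound 1 gives only a limit, > 50000 nM, because the assay reports no number at that point (the limit of > 50000 nM in this assay, at which 1 of the 2 values shown sits). Compound 2 `COc1ccc(-c2cc3cc(C)ccc3c(-c3ccc(O)cc3)n2)cc1OC` carries a 4-hydroxyphenyl where compound 1 carried a different methoxyphenyl, and in this assay compound 2 gives 18100 nM. That change produced an at least 2.7-fold lower number from compound 1 to compound 2 (0.44 log units; beyond the scatter). For the measured compounds named here, compound 2 therefore holds the only genuine number in this set; the one other value is a limit.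

Compound 3 `COc1ccc(-c2nc(-c3ccc(OC)c(OC)c3)cc3cc(C)ccc23)cc1` differs from compound 2 by methyl in place of hydrogen on an oxygen on an aromatic ring. Going by the values given here, the single measured step bears on this only loosely: it shows that removing a methoxy for a hydroxy on the aromatic carbon lowered the number by a modest amount, while compound 3 restores a methoxy, though at a different position than in compound 1. The expected direction is therefore a higher number, and the expected size of that step is a 1.9-fold higher number from compound 2 to compound 3 (0.29 log units; within the scatter). Compound 3 is expected to give 35000 nM, within a range from 15000 nM to 80000 nM.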

Compound 3, half-maximal inhibitory concentration: > 50000 nM
Compound 3 ended at the assay's limit (the forecaster's own chance of this, stated with the estimate: 40%); middle value at least 1.4-fold (0.15 log units) away from the limit.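

Putting methyl in place of hydrogen on the oxygen of the 4-hydroxyphenyl gives, in this assay, an at least 2.7-fold higher number from compound 2 to compound 3 (0.44 log units; beyond the scatter). So the change from hydroxy to methoxy at this one spot is enough to take the compound out of the measurable range, and among these three compounds only the one with a free hydroxy, compound 2, gives a real number. The step between compound 1 and compound 3 cannot be read, and the 3-methoxyphenyl and 4-methoxyphenyl compounds cannot be ranked against each other, while the step from the hydroxy compound remains only a minimum size: the limit of > 50000 nM in this assay, at which 2 of the 3 values shown sit.

The compounds shown leave open whether the free hydroxy itself matters or only the absence of a cap on that oxygen, since they hold no other group there, such as an ethyl or a longer chain, and neither an amine nor a carboxylic acid in place of the hydroxy. Also open, from the compounds shown here alone, is whether any replacement on this ring could bring the number well below that of compound 2, 18100 nM.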